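A few compounds are considered here, and "the series" means these few. Any claim that something is new, unique, unknown or untested is made for them only; others in the source may bear on it.

Measured in an ADME assay on HepG2 cells (Homo sapiens) for cytotoxicity, read by XTT assay, with a stated time of 48 h; on this read-out higher numbers stand for lower toxicity in this test and lower numbers for higher toxicity in this test:
- compound 1 `CCCC(=O)C1=C(O)C[C@@H](CC)OC1=O`: > 100 ug/mL (a limit of the assay, not a number)
- compound 2 `CCCCCCCC[C@@H]1CC(O)=C(C(=O)CCC)C(=O)O1`: 30 ug/mL

Going by the values given here, compound 2 holds the only actual number so far, so it cannot yet be ranked against another number. Compound 3 `CCCCCCCCCCC[C@@H]1CC(O)=C(C(=O)CCC)C(=O)O1` differs from it by propyl in place of hydrogen on a saturated chain carbon, eight bonds along the chain from a saturated ring carbon. Among the compounds with values here, the one measured step that bears on this also lengthens a chain, adding hexyl: an at least 3.3-fold lower number from compound 1 to compound 2 (0.52 log units; beyond the scatter). Adding propyl is a smaller change, so a smaller step in the same direction is expected, towards higher toxicity. The estimated step is a 1.7-fold lower number from compound 2 to compound 3 (0.22 log units; within the scatter). For compound 3 the expected value is 18 ug/mL, with an estimated range of 7 ug/mL to 45 ug/mL.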

Compound 3, half-maximal cytotoxic concentration: 19 ug/mL
The estimate for compound 3 lay 1.1-fold (0.02 log units) below the measured number; measured number inside the range.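

In this assay, adding propyl gives a 1.6-fold lower number from compound 2 to compound 3 (0.20 log units; within the scatter), so at this position the longer chain brings no change that stands clear of the usual scatter. Going by these compounds alone, this is the first chain step here measured between two actual numbers. The earlier step could not offer that, as compound 1, where it starts, holds a limit and not a number: the limit of > 100 ug/mL in this assay, at which 1 of the 3 values shown sits.

Going by these compounds, whether a still longer chain would give a difference beyond the scatter stays open. So does what an amine or a carboxylic acid at the end of the chain would do.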